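The source may report more compounds than this note shows. Statements on the series, on what has been measured and on what is new or still open speak of the compounds shown alone.

Compound 1 `Cn1nccc1-c1cccc2c1CCC2c1ncc[nH]1`: 278 nM
Compound 2 `Cn1cc(-c2cccc3c2CCC3c2ncc[nH]2)cn1`: > 2900 nM

In a functional assay on CHO cells for agonist activity at Alpha-1A adrenergic receptor (Homo sapiens), read by FLIPR and calcium flux (a higher number here means that more compound is needed for the effect, a lower number that less compound is needed), compound 1 gives 278 nM. For compound 2 only a limit of the assay is known, > 2900 nM (the limit of > 2900 nM in this assay, at which 1 of the 2 values shown sits); it therefore sits on the weak side of what has been measured. Going by the values given here, the single measured step, an at least 10-fold higher number from compound 1 to compound 2 (1.01 log units; beyond the scatter), changed the group at this same position. Compound 3 `CCS(=O)(=O)Nc1cccc2c1CCC2c1ncc[nH]1` carries (ethylsulfonyl)amino in place of 1-methyl-1H-pyrazol-4-yl on an aromatic carbon. Among the compounds with values here, no measured pair sets a sulfonamide against a pyrazole, so the direction is open. The step expected here is an at least 4.8-fold lower number from compound 2 to compound 3 (0.68 log units; beyond the scatter). Compound 3 is expected near 600 nM, within 100 nM to 5000 nM.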

Compound 3, half-maximal effective concentration: 32 nM
Compound 3: middle estimate off by 19-fold (1.27 log units), on the high side, outside the stated range (below it).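

In this assay, (ethylsulfonyl)amino in place of 1-methyl-1H-pyrazol-4-yl gives an at least 90-fold lower number from compound 2 to compound 3 (1.95 log units; beyond the scatter), and in place of 1-methyl-1H-pyrazol-5-yl gives an 8.7-fold lower number from compound 1 to compound 3 (0.94 log units; beyond the scatter). This aromatic carbon therefore does not depend on a pyrazole: a group with no ring gives the lowest number of the three compounds. The value of compound 2 is a limit, so the step from it is only a bound: the limit of > 2900 nM in this assay, at which 1 of the 3 values shown sits.

Which part of the (ethylsulfonyl)amino group carries the change stays open: the sulfonyl, the amino hydrogen or the ethyl chain. A methylsulfonylamino group, a carboxamide or a longer chain on the sulfur would separate these parts.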